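Swapping One Phenyl Group at the Cytotoxicity Limit

The source may hold more compounds than are shown below. What is called first, only, known or untested is meant among the compounds shown, and "the series" means these compounds.

Compound 1 `CC(=O)Nc1ccc2oc(-c3ccnc(C(=O)N4CC5CC4CN5C(c4ccccc4)c4nnn(C)n4)c3)nc2c1`: > 50000 nM, a limit
Compound 2 `CC(=O)Nc1ccc2oc(-c3ccnc(C(=O)N4CCN(C(c5cccc(F)c5)c5nnn(C)n5)CC4)c3)nc2c1`: > 50000 nM, a limit

Both compounds were tested in an ADME assay on MDCK cells (Canis lupus familiaris) for cytotoxicity (on this read-out lower numbers stand for higher toxicity in this test and higher numbers for lower toxicity in this test), and neither gave a number. Compound 2 stands at the limit of > 50000 nM in this assay, at which 2 of the 2 values shown sit.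

Compound 3 `CC(=O)Nc1ccc2oc(-c3ccnc(C(=O)N4CCN(C(c5ccc(C)cc5)c5nnn(C)n5)CC4)c3)nc2c1` keeps the shared core of compound 2 and changes one group: 4-methylphenyl in place of 3-fluorophenyl on a saturated chain carbon bound to an amine nitrogen in a ring and an aromatic carbon.

Among the measured compounds shown here, no pair of measured compounds differs in one place, so the data offer no measured step by which to size this change. The expectation rests only on compound 2, whose reading of > 50000 nM is a limit and not a number. In this assay, no change beyond the usual scatter is expected in either direction, and the estimated step is a number no higher from compound 2 to compound 3 (the limit leaves the size open). For compound 3 the expected value is 50000 nM, with an estimated range from 25000 nM to 100000 nM. The assay is expected to report only a limit once more.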

Compound 3, half-maximal cytotoxic concentration: > 50000 nM
Compound 3 gave a limit, no number; the forecaster's own chance of this, stated with the estimate: 85%; the middle value sits exactly at the limit.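

In this assay compound 3 gives > 50000 nM, a limit and not a number. Compound 2 also reads as a limit, so no step can be read between compound 2 and compound 3. The compounds shown leave open how far any of them lies from that limit, and so what 4-methylphenyl in place of 3-fluorophenyl does in this test: the limit of > 50000 nM in this assay, at which 3 of the 3 values shown sit.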